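Thiophene to phenyl on the amide of compound 1

The source may report more compounds than this note shows. Statements on the series, on what has been measured and on what is new or still open speak of the compounds shown alone.

Measured so far in an assay on CHO cells for displacement of a labelled ligand from Alpha-1B adrenergic receptor (Homo sapiens); on this read-out lower numbers stand for stronger inhibition and higher numbers for weaker inhibition:
compound 1 `COc1cc2nc(N3CCN(C(=O)c4cccs4)[C@H]4CCCC[C@H]43)nc(N)c2cc1OC` gives 0.24 nM
compound 2 `COc1cc2nc(N3CCN(C(=O)c4ccc[nH]4)[C@H]4CCCC[C@H]43)nc(N)c2cc1OC` gives 3.16 nM
compound 3 `COc1cc2nc(N3CCN(C(=O)c4ccccn4)[C@H]4CCCC[C@H]43)nc(N)c2cc1OC` gives 5.89 nM

Compound 1 gives the lowest number of the three; its steps to compound 2 and compound 3 both lie beyond the scatter. Compound 4 `COc1cc2nc(N3CCN(C(=O)c4ccccc4)[C@H]4CCCC[C@H]43)nc(N)c2cc1OC` is not yet measured. It differs from compound 1 in one place: phenyl in place of thiophen-2-yl on a carbonyl carbon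

The measured steps that bear on this exchange are those that replace the same group at the same carbonyl carbon: a 13-fold higher number from compound 1 to compound 2 (1.12 log units; beyond the scatter) and a 25-fold higher number from compound 1 to compound 3 (1.39 log units; beyond the scatter). Both replacements bring in a ring with a hetero atom and both raise the number by a large margin. Between those two products the difference is small: a 1.9-fold higher number from compound 2 to compound 3 (0.27 log units; within the scatter). Among the measured compounds shown here, the entering group here is a six-membered ring of carbon only, carrying no donor and no acceptor, so none of the measured steps is a direct match. The expectation is that compound 4 moves at most modestly from compound 1, with a rise more likely than a fall, and that the step stays within the scatter or only slightly beyond it: a 2.1-fold higher number from compound 1 to compound 4 (0.32 log units; beyond the scatter). The estimate for compound 4 in this assay is therefore 0.5 nM, in a range from 0.15 nM to 2 nM.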

Compound 4, inhibition constant: 0.49 nM
The estimate for compound 4 lay 1.0-fold (0.01 log units) above the measured number; low and high end bracket the measured number.
By their numbers in this assay, from the lowest: compound 1; then compound 4; then compounds 2 and 3 (each within the scatter of the next).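

In this assay the carbonyl carbon also accepts a ring of carbon only: a 2.0-fold higher number from compound 1 to compound 4 (0.31 log units; beyond the scatter) is a modest rise, so thiophen-2-yl is not required for a low number, though compound 1 stays lowest. The nitrogen-bearing rings are clearly separated from phenyl, with a 12-fold lower number from compound 3 to compound 4 (1.08 log units; beyond the scatter) and a 6.4-fold lower number from compound 2 to compound 4 (0.81 log units; beyond the scatter) as the steps. Among these four compounds the rings with nitrogen give the higher numbers at both ring sizes, and no compound goes against this, so ring size alone does not sort the series.

No measured information at hand accounts for this order. Also open, as far as these compounds go, is how a phenyl ring carrying a methoxy group or a chlorine atom, or a non-aromatic cyclohexyl group on the same carbonyl carbon, would read.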